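The source may report more compounds than this note shows. Statements on the series, on what has been measured and on what is new or still open speak of the compounds shown alone.

In a functional assay on HL-60 cells (Homo sapiens) for antiproliferative activity, read by sulforhodamine B assay, with a stated time of 72 h (a higher number here means a weaker inhibitor, a lower number a stronger inhibitor), compound 2 (`Fc1ccccc1NC(=S)N/N=C/c1ccc2ccccc2n1`) gives > 100000 nM, which is a limit of the assay and not a number. Compound 3 (`NC(=S)N/N=C/c1cc2cccnc2s1`) gives > 100000 nM, which is also a limit. Within the data shown here, these two results both sit at the limit of > 100000 nM in this assay, at which 2 of the 3 values shown sit, and no single-change step connects compound 3 to the others. Compound 1 (`FC(F)(F)c1ccccc1NC(=S)N/N=C/c1ccc2ccccc2n1`), by contrast, gives a true number of 13200 nM.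

The next compound is compound 4 (`S=C(N/N=C/c1ccc2ccccc2n1)Nc1cccc(Br)c1`), which carries 3-bromophenyl in place of 2-fluorophenyl on an amide-type nitrogen, as follows: 3-bromophenyl in place of 2-fluorophenyl on an amide-type nitrogen. Among the measured compounds shown here, only one measured step bears on this change. With fluoro in place of trifluoromethyl on an aromatic carbon, it is an at least 7.5-fold higher number from compound 1 to compound 2 (0.87 log units; beyond the scatter), and on that evidence replacing the 2-fluorophenyl is expected to bring the number down in this assay. That step concerns a different substituent, so it guides the direction better than the size, and compound 4 may itself stay at the limit. The expected change is an at least 3.3-fold lower number from compound 2 to compound 4 (0.52 log units; beyond the scatter), a move toward stronger inhibition of about the size of the measured step. For compound 4 the estimated value is 30000 nM, with an expected range from 8000 nM to 100000 nM.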

Compound 4, half-maximal inhibitory concentration: 53800 nM
The estimate for compound 4 lay 1.8-fold (0.25 log units) below the measured number; low and high end bracket the measured number.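

In this assay, 3-bromophenyl in place of 2-fluorophenyl on the amide-type nitrogen gives an at least 1.8-fold lower number from compound 2 to compound 4 (0.26 log units; that floor lies within the scatter). Compound 4 joins compound 1 in giving a true number, so a measurable value with this shared core does not require the trifluoromethyl group of compound 1, whose phenyl ring compound 4 replaces with 3-bromophenyl. For compound 2, the result of > 100000 nM is a limit and not a number, so only a floor for the step can be read and its true size remains unknown: the limit of > 100000 nM in this assay, at which 2 of the 4 values shown sit.

The names 2-fluorophenyl and 3-bromophenyl differ in both the halogen and its number on the phenyl ring, and the compounds shown do not separate these two differences. They also leave open how the phenyl ring on this nitrogen would fare with a different kind of substituent, such as a methoxy group, an amine or a carboxylic acid, and whether the change seen here would carry over to any such group.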